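The compounds below may be only part of what the source reports. "The series", "measured", "known", "first", "only" and "open" are said of these compounds alone.

Measured in a functional assay on HeLa cells (Homo sapiens) for antiproliferative activity, with a stated time of 24 h; on this read-out higher numbers stand for weaker inhibition and lower numbers for stronger inhibition
- compound 1 `N#Cc1ccccc1CN1CCc2c(sc(NC(=O)c3ccccc3Cl)c2C(N)=O)C1` gives > 50000 nM as a limit only
- compound 2 `NC(=O)c1c(NC(=O)c2ccccc2Cl)sc2c1CCN(C(=S)Nc1ccccc1)C2` gives 46700 nM in this series
- compound 3 `NC(=O)c1c(NC(=O)c2ccccc2Cl)sc2c1CCN(C(=S)Nc1ccccc1F)C2` gives 28700 nM in this series

Going by the values given here, compound 3 carries one of only two numbers, and it stands level with compound 2 within the scatter. Compound 1 sits at the limit, so its steps are floors and say little: the one that matters here is an at least 1.7-fold lower number from compound 1 to compound 3 (0.24 log units; that floor lies within the scatter) and it fixes no size.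

Compound 4 `COc1ccccc1NC(=S)N1CCc2c(sc(NC(=O)c3ccccc3Cl)c2C(N)=O)C1` changes one group of compound 3 methoxy in place of fluoro on an aromatic carbon and the change is methoxy in place of fluoro on an aromatic carbon, ortho to a large group. Among the compounds with values here, one measured step touches this substituent, namely a 1.6-fold lower number from compound 2 to compound 3 (0.21 log units; within the scatter) and no more. Within the data shown here, no measured compound carries methoxy, so the size of this exchange is unknown, and the one relevant step gives no ground for a shift beyond the scatter in either direction.

The expected change is a 1.1-fold higher number from compound 3 to compound 4 (0.05 log units; within the scatter) and it is not expected to leave the scatter. For compound 4 the estimated value is 32000 nM with an expected range from 15000 nM to 50000 nM in this assay and a real chance of a reading at the limit.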

Compound 4, half-maximal inhibitory concentration: > 50000 nM
Compound 4 gave a limit, no number (the forecaster's own chance of this, stated with the estimate: 20%); middle value at least 1.5-fold (0.19 log units) from the limit.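

In this assay compound 4 gives > 50000 nM, which is a limit of the assay and not a number. The exchange of fluoro for methoxy on the aromatic carbon ortho to a large group reads as an at least 1.7-fold higher number from compound 3 to compound 4 (0.24 log units; that floor lies within the scatter), and the exchange of hydrogen for methoxy reads as an at least 1.0-fold higher number from compound 2 to compound 4 (0.02 log units; that floor lies within the scatter); both are floors within the scatter, so neither fixes a size nor establishes a real shift. This place now carries hydrogen, fluoro and methoxy, and methoxy adds only that this substituent can leave the reading at the limit, while the step between compound 1 and compound 4 cannot be read, and the two steps above remain floors: the limit of > 50000 nM in this assay, at which 2 of the 4 values shown sit.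

Still open, from the compounds shown here alone, is whether any substituent at this place gives a number clearly separated from those of compound 2 and compound 3, and a hydroxyl, a dimethylamino group or a carboxylic acid on the same aromatic carbon would test that. Also open is how large the loss on going to methoxy really is, since the compounds shown give it no upper bound.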